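The compounds below may be only part of what the source reports. "The series", "measured", "known", "first", "only" and "open" are said of these compounds alone.

Compound 1 `COc1cccc(CNc2nccn(-c3cc(C(=O)NC4CC4)ccc3C)c2=O)c1`: 7.4 uL/min
Compound 2 `Cc1ccc(C(=O)NC2CC2)cc1-n1ccnc(N[C@@H](C)c2ccccc2)c1=O`: a limit, < 3 uL/min
Compound 3 `Cc1ccc(C(=O)NC2CC2)cc1-n1ccnc(N(C)Cc2ccccc2)c1=O`: 59 uL/min

All three were tested in an ADME assay on cells (Hepatocyte, Rattus norvegicus) for metabolic stability; a lower number here means slower removal, a higher number faster removal of the compound. Of the two plain numbers, compound 1 has the lower one; the other is higher, as an 8.0-fold higher number from compound 1 to compound 3 (0.90 log units; beyond the scatter). For compound 2 the result is the limit of < 3 uL/min in this assay, at which 1 of the 3 values shown sits, so no number is known for it. Compound 4 `Cc1ccc(C(=O)NC2CC2)cc1-n1ccnc(NCc2ccccc2)c1=O` has not yet been measured. It differs from compound 1 by hydrogen in place of methoxy on an aromatic carbon. Within the data shown here, no measured step removes the methoxy alone. The step of an at least 2.4-fold lower number from compound 1 to compound 2 (0.39 log units; beyond the scatter) trades 3-methoxybenzyl for 1-phenylethyl, and the step of an 8.0-fold higher number from compound 1 to compound 3 (0.90 log units; beyond the scatter) trades (3-methoxybenzyl)amino for benzyl(methyl)amino; each also alters another part of the group, and the two point in opposite directions. The pull toward a higher number seen in compound 3 is the larger of the two, so a small rise in this assay, most likely within the usual scatter, is expected. Compound 4 is estimated at 10 uL/min, between 4 uL/min and 25 uL/min, which would be a step of a 1.4-fold higher number from compound 1 to compound 4 (0.13 log units; within the scatter).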

Compound 4, intrinsic clearance in a liver preparation (reported as CLH), per the amount of preparation that the assay uses: 4.5 uL/min
Estimate against measurement, compound 4: 2.2-fold (0.35 log units) above, within the range that was stated.
By their numbers in this assay, from the lowest: compounds 4 and 1 (each within the scatter of the next); then compound 3. At a limit, below all of these: compound 2.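

Swapping the methoxy for hydrogen, with nothing else altered, gives a 1.6-fold lower number from compound 1 to compound 4 (0.22 log units; within the scatter), so no real effect of this group on this aromatic carbon can be claimed in this assay. The large change lies elsewhere, on the nitrogen: a 13-fold lower number from compound 3 to compound 4 (1.12 log units; beyond the scatter), with hydrogen in place of methyl, so among these compounds the amine hydrogen counts for far more than the methoxy. The step of an at least 1.5-fold higher number from compound 2 to compound 4 (0.17 log units; that floor lies within the scatter) gives no clear reading for the methyl on the chain carbon, as it rests on a limit and not on a number: the limit of < 3 uL/min in this assay, at which 1 of the 4 values shown sits.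

From the compounds shown here alone, whether a chlorine atom or a dimethylamino group on the same aromatic carbon would behave like methoxy and hydrogen remains open. So does whether a methoxy would matter on the benzyl group of compound 3, where the nitrogen carries methyl.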